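The compounds below may be only part of what the source reports. "The series", "measured", "known", "first", "only" and "open" are said of these compounds alone.

Compound 1 `CCc1ccc(-c2nc(N)c3cc(Cc4ccccc4)sc3n2)o1`: 223 nM
Compound 2 `CC(C)c1ccc(-c2nc(N)c3cc(Cc4ccccc4)sc3n2)o1`: 283 nM
Compound 3 `Nc1nc(-c2cnco2)nc2sc(Cc3ccccc3)cc12`: 106 nM

In a functional assay on CHO-K1 cells for antagonist activity at adenosine receptor A1 (Homo sapiens), read by a beta-galactosidase reporter and cAMP accumulation, with stated times of 15 min and 6 h (a higher number here means a weaker inhibitor, a lower number a stronger inhibitor), compound 3 gives 106 nM, the lowest of the three numbers; the two steps that lead to it, a 2.1-fold lower number from compound 1 to compound 3 (0.32 log units; beyond the scatter) and a 2.7-fold lower number from compound 2 to compound 3 (0.43 log units; beyond the scatter), both lower the number modestly. The remaining step, a 1.3-fold higher number from compound 1 to compound 2 (0.10 log units; within the scatter), changes a different part of the molecule and stays within the scatter.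

Compound 4 `Nc1nc(-c2cccc(F)c2)nc2sc(Cc3ccccc3)cc12` differs from compound 3 by 3-fluorophenyl in place of 1,3-oxazol-5-yl on an aromatic carbon. Among the compounds with values here, no measured step swaps a five-membered ring for a six-membered carbon ring at this place, so the two modest steps into compound 3 bear on it only loosely. The change is therefore expected to be small and uncertain in direction: a 1.4-fold higher number from compound 3 to compound 4 (0.15 log units; within the scatter). Compound 4 is estimated at 150 nM, between 40 nM and 550 nM.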

Compound 4, inhibition constant: 123 nM
For compound 4 the middle estimate is 1.2-fold (0.09 log units) above the measured one, and the stated range covers the measured number.
By their numbers in this assay, from the lowest: compounds 3, 4, 1 and 2 (each within the scatter of the next, the first and the last beyond it).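

In this assay, a change to 3-fluorophenyl, which carries no hydrogen-bond acceptors, gives a 1.2-fold higher number from compound 3 to compound 4 (0.06 log units; within the scatter), so this place between two ring nitrogen atoms accepts a six-membered aromatic ring of carbon only as well as it accepts 1,3-oxazol-5-yl. Against the furans, 3-fluorophenyl gives a 2.3-fold lower number from compound 2 to compound 4 (0.36 log units; beyond the scatter) and a 1.8-fold lower number from compound 1 to compound 4 (0.26 log units; within the scatter), so only the step from 5-isopropylfuran-2-yl lies beyond the scatter. Nothing shown here explains these results. On these data alone, what a plain phenyl without the fluorine would give remains open, as do 4-fluorophenyl and 3-methoxyphenyl at this place.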